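The source may hold more compounds than are shown below. What is called first, only, known or untested is meant among the compounds shown, and "the series" means these compounds.

Measured compounds:
compound 1, `CCOC(=O)CO/N=C(/c1ccc(OC)c(OC)c1OC)c1cccc2ccccc12`, 16400 nM
compound 2, `COc1ccc(/C(=C\c2ccc(F)cc2)c2cccc3ccccc23)c(OC)c1OC`, 16200 nM
compound 3, `COc1ccc(/C(=C/c2ccc(C)cc2)c2cccc3ccccc23)c(OC)c1OC`, 8310 nM

In a functional assay on MDA-MB-231 cells (Homo sapiens) for inhibition, read by sulforhodamine B assay, with a stated time of 48 h (a lower number here means a stronger inhibitor, a higher number a weaker inhibitor), compound 3 gives the lowest of the three numbers, yet its gap to compound 2 and its gap to compound 1 both fall within the usual scatter, so no order among the three can be read from these values. Compound 4, `COc1ccc(/C(=C/c2ccc(F)cc2)c2cccc3ccccc23)c(OC)c1OC`, has not been measured. It differs from compound 3 in one place: fluoro in place of methyl on an aromatic carbon. Going by the values given here, no measured pair here shows a step of this kind, so there is no direct guide to its size. Compound 2, which also carries a 4-fluorophenyl group, gives 16200 nM in this assay, a number within the scatter of compound 3. On that basis the step is expected to be small, of the size a 1.4-fold higher number from compound 3 to compound 4 (0.16 log units; within the scatter), and not beyond the scatter in either direction. For compound 4 the estimated value in this assay is 12000 nM, with a range from 5000 nM to 30000 nM.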

Compound 4, half-maximal inhibitory concentration: > 20000 nM
Compound 4: no number, only a limit (the forecaster's own chance of this, stated with the estimate: 5%); middle value at least 1.6-fold (0.22 log units) from the limit.
By their numbers in this assay, from the lowest: compounds 3, 2 and 1 (each within the scatter of the next). At a limit, above all of these: compound 4.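

Compound 4 gives no number in this assay, only a limit: the limit of > 20000 nM in this assay, at which 1 of the 4 values shown sits.

Fluoro in place of methyl on this aromatic carbon, para to a large group, gives an at least 2.4-fold higher number from compound 3 to compound 4 (0.38 log units; beyond the scatter) and is the first step in this set to lie beyond the scatter, so this position is not indifferent to the change from 4-methylphenyl to 4-fluorophenyl. The pair that shares all atoms and bonds shows an at least 1.2-fold higher number from compound 2 to compound 4 (0.09 log units; that floor lies within the scatter) and so gives no firm reading of what the drawn configuration of the double bond contributes: the fact that compounds 2 and 4 differ only in the configuration as drawn.

On these data alone, what a chloro, a methoxy or an amine on the same carbon would give in this assay remains open. Also open, as far as these compounds go, is how far compound 4 lies past its limit, and so how large either step truly is.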